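The compounds below may be only part of what the source reports. "The series", "measured", "known", "first", "only" and "open" are said of these compounds alone.

Working notes on the series. Compound 1 `O=C1COCCN1c1ccc(C2CC(c3ccc([N+](=O)[O-])o3)=NO2)cc1F` and compound 2 `O=C1COCCN1c1ccc(C2CC(c3ccc([N+](=O)[O-])o3)=NO2)cn1` share a core and differ only in the six-membered aromatic ring that carries the 3-oxomorpholin-4-yl group. In an ADME assay on Caco-2 cells (Homo sapiens) for permeability, read by HPLC, with a stated time of 2 h (on this read-out higher numbers stand for higher permeability and lower numbers for lower permeability), compound 1 gives 154 nm/s, and in this assay compound 2 gives 86.1 nm/s. Compound 2 stands at the lowest of the two numbers, but its gap to compound 1 lies within the scatter, so the two cannot be put in order.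

Compound 3 `CN1CCN(c2ccc(C3CC(c4ccc([N+](=O)[O-])o4)=NO3)cn2)C(=O)C1` is not yet measured in this assay. Its change from compound 2 is 4-methyl-2-oxopiperazin-1-yl in place of 3-oxomorpholin-4-yl on an aromatic carbon. For the measured compounds named here, no measured pair in the set shows this change, so its effect is open. The expected step from compound 2 to compound 3 is a 1.6-fold lower number from compound 2 to compound 3 (0.19 log units; within the scatter), a modest fall that may well stay within the scatter. For compound 3 in this assay the estimate is 55 nm/s, with a range from 25 nm/s to 120 nm/s.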

Compound 3, apparent permeability: 366 nm/s
Compound 3: the middle estimate sits 6.7-fold (0.82 log units) below what was measured; the whole stated range lies below it.
By their numbers in this assay, from the lowest: compounds 2 and 1 (each within the scatter of the next); then compound 3.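

In this assay, 4-methyl-2-oxopiperazin-1-yl in place of 3-oxomorpholin-4-yl on an aromatic carbon gives a 4.3-fold higher number from compound 2 to compound 3 (0.63 log units; beyond the scatter) and thus shows that the number responds to the group at this position, next to the ring nitrogen, beyond the scatter. Compound 1 and compound 2 could not show this, since they differ only in the aromatic ring and their gap lies within the scatter. The two groups match in hydrogen-bond donors, hydrogen-bond acceptors and net charge, and no measurement at hand accounts for the rise.

Open, from the compounds shown here alone, is whether the rise depends on the methyl group, which 2-oxopiperazin-1-yl with a hydrogen on that ring nitrogen, or an ethyl or acetyl group there, would help to settle. Also open, going by these compounds, is whether the same change on the core of compound 1 gives a step of similar size.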